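Chloro on the anilino ring: still beyond the limit

This account rests on a few compounds, and the source may have more. Where it says the series, first, only, none or still open, it means among the compounds named here.

Of the compounds shown here, three of one series have been tested so far, and all of them give the same kind of result. Compound 1 `C=C[C@@](C)(/C=C/c1ccc(O)cc1)CCCO` is the smallest of the three. In a functional assay on SEM cells (Homo sapiens) for cytotoxicity, with a stated time of 72 h (on this read-out higher numbers stand for an effect only at larger amounts of compound and lower numbers for an effect already at smaller amounts), compound 1 gives > 36600 nM, which is a limit of the assay rather than a number. Compound 2 `C=C[C@@](C)(/C=C/c1ccc(Nc2ccccc2)cc1)CCC=C(C)C` carries an anilino group on the shared core. In this assay compound 2 gives > 36600 nM, again a limit of the assay. Compound 3 `C=C[C@@](C)(/C=C/c1ccc(Nc2cccc(OC(F)(F)F)c2)cc1)CCC=C(C)C` adds a trifluoromethoxy on an aromatic carbon of the anilino group. In this assay compound 3 gives > 36600 nM, also a limit. The step that the two limits leave unreadable from compound 2 to compound 3 therefore cannot be read, and the only thing that stands out is the limit of > 36600 nM in this assay, at which 3 of the 3 values shown sit.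

Compound 4 `C=C[C@@](C)(/C=C/c1ccc(Nc2ccc(Cl)cc2)cc1)CCC=C(C)C` is the compound still to be measured. It differs from compound 2 by chloro in place of hydrogen on an aromatic carbon. Going by the values given here, no measured step shows any change leaving the limit, and nothing in the measured compounds points to a direction for this change in this assay. The step that the limit leaves unreadable from compound 2 to compound 4 is therefore an estimate that expects nothing beyond the scatter. Compound 4 is expected to give 40000 nM, with a range from 15000 nM to 150000 nM, and most likely another limit.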

Compound 4, half-maximal effective concentration: > 36600 nM
Compound 4 gave a limit, no number; the forecaster's own chance of this, stated with the estimate: 85%; the middle value does not contradict the limit.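

Compound 2 and compound 4 both sit at a limit of the assay, so the step between them, chloro in place of hydrogen on an aromatic carbon, cannot be read. All that can be said is this: the limit of > 36600 nM in this assay, at which 4 of the 4 values shown sit.

The compounds shown leave open whether any member of this series gives an actual number in this assay, and how far each lies from the limit.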